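This account rests on a few compounds, and the source may have more. Where it says the series, first, only, none or still open, it means among the compounds named here.

Working notes on the series. In a functional assay on the whole organism (strain Wistar) for inhibition, with Rattus norvegicus as the target, read by paw edema, with stated times of 30 min and 3 h, at a dose of 100 mg/kg by the oral route (a lower number here means less inhibition, a higher number more inhibition at the dose given (going by the name of the read-out)), compound 1 `CCCCOc1cc(C(=O)NCC)nn1-c1ccccc1` gives 0%, compound 2 `CCCCOc1cc(C(=O)N(C)C)nn1-c1ccccc1` gives 18.7% and compound 3 `CCCCOc1cc(C(=O)NCCC)nn1-c1ccccc1` gives 51.2%, so compound 3 stands highest of the three, with compound 2 nearest and compound 1 furthest. Compound 4 `CCCCOc1cc(C(=O)NCCO)nn1-c1ccccc1` differs from compound 3 in one place: hydroxy in place of methyl on a saturated chain carbon, two bonds along the chain from an amide-type nitrogen. The step that bears on the same chain carbon is a number 51.2 percentage points higher from compound 1 to compound 3 (beyond the scatter), a large rise, and a number 32.5 percentage points higher from compound 2 to compound 3 (beyond the scatter) was also large. Going by the values given here, no measured step puts a hydroxy group at that carbon, so the direction rests on analogy only. Since compound 1 with the shorter chain sits at 0%, a fall is expected. The expected step is a number 26.2 percentage points lower from compound 3 to compound 4 (beyond the scatter). Compound 4 is estimated at 25%, within 0% to 55%.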

Compound 4, a percentage reported as inhibition, in the whole organism at one dose (the size of the read-out at that dose, not a potency): 61.2%
The estimate for compound 4 lay 36.2 percentage points below the measured number, and the stated range ends below it.
By their numbers in this assay, from the lowest: compound 1; then compound 2; then compounds 3 and 4 (each within the scatter of the next).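

In this assay hydroxy in place of methyl on this chain carbon gives a number 10 percentage points higher from compound 3 to compound 4 (within the scatter) and so does not separate the two groups: the added hydrogen-bond donor and acceptor leave the number where methyl had it. Hydroxy in place of hydrogen at the same carbon gives a number 61.2 percentage points higher from compound 1 to compound 4 (beyond the scatter) and the change from the dimethylamino amide gives a number 42.5 percentage points higher from compound 2 to compound 4 (beyond the scatter) so the (2-hydroxyethyl)amino amide, like the propylamino amide, stands clear of both lower compounds. Nothing measured here accounts for this.

Going by these compounds, whether a methoxy, an amine or a carboxylic acid at that carbon keeps the number remains open. So does the effect of a longer chain such as butylamino.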